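The source may hold more compounds than are shown below. What is called first, only, known or untested is meant among the compounds shown, and "the series" means these compounds.

Compound 3 `Cc1cccc(C(=O)/C=C/c2ccc3c(c2)B(O)OC3)c1` gives 2900 nM in a functional assay on SK-OV-3 cells (Homo sapiens) for cytotoxicity, read by MTT assay, with a stated time of 48 h (a lower number here means a stronger inhibitor, a higher number a weaker inhibitor), the lowest of the three numbers shown, although compound 1 `O=C(/C=C/c1ccc2c(c1)B(O)OC2)c1ccc(Cl)cc1` gives 3700 nM and compound 2 `O=C(/C=C/c1ccc2c(c1)B(O)OC2)c1ccc(Br)cc1` gives 4500 nM, so that all three sit within the scatter of one another. The steps of a 1.3-fold lower number from compound 1 to compound 3 (0.11 log units; within the scatter) and a 1.6-fold lower number from compound 2 to compound 3 (0.19 log units; within the scatter) show that swapping one aryl group on the carbonyl for another leaves this assay essentially unchanged, and a 1.2-fold higher number from compound 1 to compound 2 (0.09 log units; within the scatter) says the same for the halogen exchange. Compound 4 `COCOc1cccc(C(=O)/C=C/c2ccc3c(c2)B(O)OC3)c1` carries methoxymethoxy in place of methyl on an aromatic carbon. Going by the values given here, no measured step touches this kind of substituent, so the data give no ground to expect a shift beyond the scatter in this assay. Compound 4 is therefore expected to give 3000 nM, between 1400 nM and 6500 nM. The expected step is a 1.0-fold higher number from compound 3 to compound 4 (0.01 log units; within the scatter).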

Compound 4, half-maximal inhibitory concentration: 11700 nM
For compound 4 the middle estimate is 3.9-fold (0.59 log units) below the measured one, outside the stated range (above it).
By their numbers in this assay, from the lowest: compounds 3, 1 and 2 (each within the scatter of the next); then compound 4.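

Methoxymethoxy in place of methyl on an aromatic carbon, meta to a large group, gives a 4.0-fold higher number from compound 3 to compound 4 (0.61 log units; beyond the scatter) in this assay and is the first step shown to leave the scatter. The earlier aryl and halogen exchanges had not shown that this assay can respond to a change at all, and here it responds to the group at this place. No measurement shown gives a reason for the shift. The compounds shown leave open whether a hydroxyl, a methoxy or an amine at this place would give a similar number. They also leave open whether a longer ether chain would move it further.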